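This account rests on a few compounds, and the source may have more. Where it says the series, first, only, none or still open, it means among the compounds named here.

Two compounds of this series have been run in an assay on isolated protein (Mus musculus) for inhibition of IL15-IL15 receptor (Homo sapiens), read by resazurin assay, with stated times of 30 min and 2.5 days; on this read-out lower numbers stand for stronger inhibition and higher numbers for weaker inhibition. Compound 1 `Cn1c(Cc2nn(C)c(=O)c3ccccc23)nnc1SCCCCCCCCCCC(=O)Nc1ccccc1Cl` gives 15000 nM, and compound 2 `CC(C)COc1ccc(NC(=O)CSc2nnc(Cc3nn(C)c(=O)c4ccccc34)n2C)cc1` gives 30000 nM; the two numbers lie within the usual scatter of each other, so neither stands apart. Compound 3 `Cn1c(Cc2nn(C)c(=O)c3ccccc23)nnc1SCCCCCCCCCC(=O)Nc1ccc(Cl)cc1Cl` is yet to be measured. It differs from compound 1 in one place: (2,4-dichlorophenyl)carbamoyl in place of ((2-chlorophenyl)carbamoyl)methyl on a saturated chain carbon, nine bonds along the chain from a sulfur. For the measured compounds named here, with no measured pair of this kind to lean on, the step from compound 1 to compound 3 is expected to stay within the scatter, no change at the digits printed from compound 1 to compound 3 (within the scatter). Compound 3 is therefore estimated at 15000 nM, with a range of 5000 nM to 45000 nM.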

Compound 3, half-maximal inhibitory concentration: 2300 nM
Compound 3: middle estimate off by 6.5-fold (0.81 log units), on the high side; the measured number lies below the stated range.
By their numbers in this assay, from the lowest: compound 3; then compounds 1 and 2 (each within the scatter of the next).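

For the compounds shown here, the far end of the chain is sensitive to change in this assay: (2,4-dichlorophenyl)carbamoyl in place of ((2-chlorophenyl)carbamoyl)methyl gives a 6.5-fold lower number from compound 1 to compound 3 (0.81 log units; beyond the scatter) and is the first step beyond the scatter. This single step brings both a shorter chain and a second chlorine, so its size cannot be divided between them. No available evidence bears on the reason for the step. Still open, on these data alone, is how far each of the two alterations would act alone. Also open, as far as these compounds go, is whether a carboxylic acid in place of the aryl amide would keep the lower number.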